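The source may report more compounds than this note shows. Statements on the series, on what has been measured and on what is new or still open speak of the compounds shown alone.

Compound 1 (`NC(=O)c1cccc(C(O)(c2ccc(C(F)(F)F)cc2)c2cccnc2)c1`) gives > 100000 nM in an ADME assay on L6 cells (Rattus norvegicus) for cytotoxicity, read by resazurin assay, with a stated time of 72 h (on this read-out lower numbers stand for stronger inhibition and higher numbers for weaker inhibition), as a limit of the assay.
Compound 2 (`CN(C)c1ccc(C(O)(c2ccc(C(F)(F)F)cc2)c2cccnc2)cc1`) gives 59100 nM in this assay as a measured number.

Among the measured compounds shown here, compound 2 holds the only true number in this assay so far. The other result is a limit (the limit of > 100000 nM in this assay, at which 1 of the 2 values shown sits). Compound 3 (`CC(C)c1ccc(C(O)(c2ccc(C(F)(F)F)cc2)c2cccnc2)cc1`) carries isopropyl in place of dimethylamino on an aromatic carbon, para to a large group (isopropyl in place of dimethylamino on an aromatic carbon). For the measured compounds named here, one measured step bears on this change, and only loosely. That step (an at least 1.6-fold lower number from compound 1 to compound 2 (0.22 log units; that floor lies within the scatter)) stays within the scatter at its floor and exchanges a whole 3-carbamoylphenyl for 4-(dimethylamino)phenyl. With so little to go on, no shift beyond the scatter is expected in this assay, and no firm direction. The expected step (a 1.3-fold lower number from compound 2 to compound 3 (0.12 log units; within the scatter)) is an estimate within the scatter. For compound 3 the estimated value is 45000 nM with an expected range from 17000 nM to 100000 nM in this assay.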

Compound 3, half-maximal inhibitory concentration: 56300 nM
Beside the measured number, compound 3's estimate is 1.3-fold (0.10 log units) below it; the measured number falls inside the stated range.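

In this assay, the exchange at this position, on an aromatic carbon para to a large group, reads a 1.0-fold lower number from compound 2 to compound 3 (0.02 log units; within the scatter), so dimethylamino and isopropyl cannot be told apart here, even though the hydrogen-bond acceptor count of the group goes from 1 to 0. The wider exchange of the whole aryl group reads an at least 1.7-fold lower number from compound 1 to compound 3 (0.24 log units; that floor lies within the scatter), and with its floor inside the scatter, 4-isopropylphenyl is not separated from 3-carbamoylphenyl. The value of compound 1 is a limit of the assay and not a number: the limit of > 100000 nM in this assay, at which 1 of the 3 values shown sits.

As far as these compounds go, whether an amine, a carboxylic acid or a longer chain at this position would shift the number beyond the scatter remains open. From the compounds shown here alone, the true distance of compound 1 from compound 3 also remains open; only a floor exists for it.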